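The source may hold more compounds than are shown below. What is called first, only, known or untested is meant among the compounds shown, and "the series" means these compounds.

Compound 1, with the structure `COc1ccc(CNC(=O)c2cc3cc(OC)c(OCCCOc4no[n+]([O-])c4S(=O)(=O)c4ccccc4)cc3oc2=O)cc1`, stands lowest of the two numbers measured in a functional assay on MDA-MB-231 cells (Homo sapiens) for inhibition, read by MTT assay, with a stated time of 48 h (on this read-out lower numbers stand for stronger inhibition and higher numbers for weaker inhibition), where compound 1 gives 780 nM. Compound 2, with the structure `COc1cc2cc(C(=O)Nc3ccccc3)c(=O)oc2cc1OCCCOc1no[n+]([O-])c1S(=O)(=O)c1ccccc1`, gives 1190 nM in this assay, and the step of a 1.5-fold higher number from compound 1 to compound 2 (0.18 log units; within the scatter) lies within the scatter. Compound 3, with the structure `COc1cc2cc(C(=O)NCCCc3ccccc3)c(=O)oc2cc1OCCCOc1no[n+]([O-])c1S(=O)(=O)c1ccccc1`, differs from compound 1 in that (phenethyl in place of 4-methoxyphenyl on a saturated chain carbon bound to an amide-type nitrogen). Going by the values given here, the only step that bears on this change, the one from compound 1 to compound 2, also altered the substituent on the amide-type nitrogen and stayed within the scatter, so no step beyond the scatter is expected here either. Compound 3 is therefore expected to give 900 nM in this assay, within a range from 450 nM to 1800 nM, which corresponds to an estimated step of a 1.2-fold higher number from compound 1 to compound 3 (0.06 log units; within the scatter).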

Compound 3, half-maximal inhibitory concentration: 760 nM
For compound 3 the middle estimate is 1.2-fold (0.07 log units) above the measured one, and the stated range covers the measured number.
By their numbers in this assay, from the lowest: compounds 3, 1 and 2 (each within the scatter of the next).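

In this assay the change from 4-methoxybenzyl to 3-phenylpropyl on the amide-type nitrogen gives (a 1.0-fold lower number from compound 1 to compound 3 (0.01 log units; within the scatter)), so the methoxy oxygen leaves and the chain changes with no shift beyond the scatter. The change from phenyl to 3-phenylpropyl gives (a 1.6-fold lower number from compound 2 to compound 3 (0.19 log units; within the scatter)), which also stays within the scatter, so all three groups at this position read alike here. No evidence accompanies these numbers to explain them. On these data alone, whether a terminal amine, a carboxylic acid or a chain longer than 3-phenylpropyl would give a step beyond the scatter remains open.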